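The source may report more compounds than this note shows. Statements on the series, on what has been measured and on what is new or still open speak of the compounds shown alone.

Measured so far:
compound 1 `CN(CC1CCN(CCCc2c[nH]c3ccc(-n4cnnc4)cc23)CC1)C(=O)Nc1ccccc1` — 6.2 nM
compound 2 `CN(Cc1ccsc1)C1CCN(CCCc2c[nH]c3ccc(-n4cnnc4)cc23)CC1` — 35 nM

In an assay on CHO cells for displacement of a labelled ligand from 5-hydroxytryptamine receptor 1B (Homo sapiens) (on this read-out higher numbers stand for weaker inhibition and lower numbers for stronger inhibition), compound 1 gives 6.2 nM. In this assay compound 2 gives 35 nM, the higher of the two numbers; the gap to compound 1 lies beyond the scatter, so compound 2 is the weaker of the pair.

Compound 3 `C[C@H](NCC1CCN(CCCc2c[nH]c3ccc(-n4cnnc4)cc23)CC1)c1ccccc1` arises from compound 2 by ((1-phenylethyl)amino)methyl in place of methyl((thiophen-3-yl)methyl)amino on a saturated ring carbon. Among the measured compounds shown here, no measured pair shares this change, so the two values above are the only guide. Compound 1 shows that a different substituent on this ring carbon can go with 6.2 nM. In this assay the expected step is a 2.3-fold lower number from compound 2 to compound 3 (0.37 log units; beyond the scatter), toward a lower number, modest in size and probably beyond the scatter, without reaching the level of compound 1. The estimate for compound 3 in this assay is 15 nM, with a range from 4 nM to 60 nM.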

Compound 3, half-maximal inhibitory concentration: 58 nM
Estimate against measurement, compound 3: 3.9-fold (0.59 log units) below; measured number inside the range.
By their numbers in this assay, from the lowest: compound 1; then compounds 2 and 3 (each within the scatter of the next).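

In this assay, ((1-phenylethyl)amino)methyl in place of methyl((thiophen-3-yl)methyl)amino on the saturated ring carbon gives a 1.7-fold higher number from compound 2 to compound 3 (0.22 log units; within the scatter), so this exchange, which swaps the five-membered aromatic ring with 1 hetero atom for a six-membered aromatic ring of carbon only and adds a defined stereocentre, leaves no readable difference. Among the compounds shown here, on the saturated chain carbon bound to a saturated ring carbon, (1-phenylethyl)amino in place of methyl(phenylcarbamoyl)amino gives a 9.4-fold higher number from compound 1 to compound 3 (0.97 log units; beyond the scatter), the first single-place comparison to show a gap beyond the scatter. No measurement at hand explains either result.

Still open, from the compounds shown here alone, is whether the opposite configuration of the 1-phenylethyl group, or a plain benzylamino group, would read differently in this assay. Also open, going by these compounds, is whether a simple acetamide on the same chain carbon would keep the level of compound 1.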